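The source may report more compounds than this note shows. Statements on the series, on what has been measured and on what is new or still open speak of the compounds shown alone.

Compound 2 `O=C(O)CCc1ccc(NC(=O)c2nnc(Cc3ccccc3)s2)cc1` gives 3670 nM in a functional assay on CHO cells for agonist activity at Free fatty acid receptor 1 (Homo sapiens), read by FLIPR and calcium flux, tested at 1 uM (a lower number here means that less compound is needed, a higher number that more compound is needed for the effect), the higher of the two numbers in hand, yet its nearest neighbour, compound 1 `Cc1cccc(OCc2nnc(C(=O)Nc3ccc(CCC(=O)O)cc3)s2)c1` with 3260 nM, lies within the scatter: the step of a 1.1-fold higher number from compound 1 to compound 2 (0.05 log units; within the scatter) is too small to rank them. Compound 3 `O=C(O)CCc1ccc(NC(=O)c2nnc(Cc3ccc(Cl)cc3)s2)cc1` differs from compound 2 by chloro in place of hydrogen on an aromatic carbon. Among the compounds with values here, no measured step alters the ring in this way, so the only comparison available, compound 1 to compound 2, is of another kind and small. Compound 3 is therefore expected near compound 2, with the step of a 1.3-fold lower number from compound 2 to compound 3 (0.12 log units; within the scatter) not beyond the scatter. The estimate for compound 3 is 2800 nM, ranging from 900 nM to 8000 nM.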

Compound 3, half-maximal effective concentration: 2390 nM
Compound 3: the middle estimate sits 1.2-fold (0.07 log units) above what was measured; low and high end bracket the measured number.
By their numbers in this assay, from the lowest: compounds 3, 1 and 2 (each within the scatter of the next).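

Chloro is tolerated on the benzyl group at this position in this assay, giving a 1.5-fold lower number from compound 2 to compound 3 (0.19 log units; within the scatter). Replacing the 3-methylphenoxy side group with 4-chlorophenyl gives a 1.4-fold lower number from compound 1 to compound 3 (0.13 log units; within the scatter), so the three side groups at this place cannot be ranked. Nothing available explains this result.

Still open, from the compounds shown here alone, is whether an amine or a nitrile in place of the chloro would move the number beyond the scatter. Going by these compounds, a longer chain in place of the benzyl carbon also remains untested in these compounds.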